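The source may report more compounds than this note shows. Statements on the series, on what has been measured and on what is new or still open speak of the compounds shown alone.

Three compounds of the series have numbers in an assay on AV12 cells for binding affinity to Neuropeptide Y receptor type 1 (Homo sapiens); on this read-out lower numbers stand for stronger inhibition and higher numbers for weaker inhibition. Compound 1 `Cc1cccc2c1nc(COc1ccc(Cl)cc1)n2CCCC1CCNCC1` gives 335 nM; compound 2 `Cc1cccc2c1nc(COc1ccc(Cl)cc1)n2CCCC1CCN(C)CC1` gives 52 nM; compound 3 `CCCN1CCC(CCCn2c(COc3ccc(Cl)cc3)nc3c(C)cccc32)CC1` gives 29 nM. Compound 3 holds the lowest of the three numbers, but its gap to compound 2 lies within the scatter, and only its gap to compound 1 lies beyond it. Going by the values given here, the steps so far read a 6.4-fold lower number from compound 1 to compound 2 (0.81 log units; beyond the scatter) and a 12-fold lower number from compound 1 to compound 3 (1.06 log units; beyond the scatter), both for methyl or propyl in place of hydrogen on the amine nitrogen in the ring, while a 1.8-fold lower number from compound 2 to compound 3 (0.25 log units; within the scatter) concerns growth of the chain already on that nitrogen. Compound 4 `Cc1cccc2c1nc(COc1ccc(Cl)cc1)n2CCCC1CCN(CCC(C)C)CC1` carries the change (isopropyl in place of methyl on a saturated chain carbon, two bonds along the chain from an amine nitrogen in a ring), again a growth of the chain rather than a change at the nitrogen itself. The step from compound 2 to compound 3 is the one that bears on it, and it stayed within the scatter; the two large steps involve the hydrogen-bearing nitrogen and do not carry over. For compound 4 in this assay a step of a 1.2-fold lower number from compound 3 to compound 4 (0.08 log units; within the scatter) is therefore expected, with nothing beyond the scatter. The estimate for compound 4 is 24 nM, expected to fall between 9 nM and 65 nM.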

Compound 4, inhibition constant: 11 nM
Compound 4: the middle estimate sits 2.2-fold (0.34 log units) above what was measured; the measured number falls inside the stated range.
By their numbers in this assay, from the lowest: compound 4; then compounds 3 and 2 (each within the scatter of the next); then compound 1.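

In this assay, growth of the chain on the amine nitrogen in a ring now counts beyond the scatter: isopropyl in place of methyl on a saturated chain carbon, two bonds along the chain from that nitrogen, gives a 2.6-fold lower number from compound 3 to compound 4 (0.42 log units; beyond the scatter), whereas the shorter growth gave only a 1.8-fold lower number from compound 2 to compound 3 (0.25 log units; within the scatter). Isobutyl in place of hydrogen on the saturated chain carbon bound to that nitrogen gives a 4.7-fold lower number from compound 2 to compound 4 (0.67 log units; beyond the scatter), and isopentyl in place of hydrogen on the nitrogen itself gives a 30-fold lower number from compound 1 to compound 4 (1.48 log units; beyond the scatter), so compound 4 holds the lowest number of the four, with all its steps beyond the scatter. Nothing available explains these steps.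

Going by these compounds, whether the step follows the added length or the isopropyl end stays open, and a straight pentyl chain on the same nitrogen would separate the two. On these data alone, how a longer chain or a benzyl group on that nitrogen would read also stays open.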